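This account rests on a few compounds, and the source may have more. Where it says the series, first, only, none or still open, it means among the compounds named here.

Compound 1 `CC1(C)S[C@@H]2/C(=C\C(=O)c3ccc(C(F)(F)F)cc3)C(=O)N2[C@H]1C(=O)OC(c1ccccc1)c1ccccc1` was tested in a functional assay on OE19 cells (Homo sapiens) for cytotoxicity, read by MTT assay, with a stated time of 48 h (a lower number here means a stronger inhibitor, a higher number a weaker inhibitor), where compound 1 gives 15600 nM. Going by the values given here, the only other compound measured there is compound 2 `CC1(C)[C@H](C(=O)OC(c2ccccc2)c2ccccc2)N2C(=O)/C(=C/C(=O)c3ccc([N+](=O)[O-])cc3)[C@H]2[S+]1[O-]`; in this assay compound 2 gives 92400 nM, so compound 1 holds the lower of the two numbers, and that gap lies beyond the scatter. Compound 3 `CC1(C)S[C@@H]2/C(=C\C(=O)OCc3ccccc3)C(=O)N2[C@H]1C(=O)OC(c1ccccc1)c1ccccc1` is not yet measured. It differs from compound 1 in one place: benzyloxy in place of 4-(trifluoromethyl)phenyl on a carbonyl carbon. Among the compounds with values here, no measured pair shows this change, so no step is known for it; compound 3 is expected to land at a somewhat higher number than compound 1, a step estimated as a 1.6-fold higher number from compound 1 to compound 3 (0.20 log units; within the scatter). Compound 3 is therefore estimated at about 25000 nM, within 8000 nM to 80000 nM.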

Compound 3, half-maximal inhibitory concentration: 8200 nM
Estimate against measurement, compound 3: 3.0-fold (0.48 log units) above; measured number inside the range.
By their numbers in this assay, from the lowest: compounds 3 and 1 (each within the scatter of the next); then compound 2.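

In this assay, benzyloxy in place of 4-(trifluoromethyl)phenyl on this carbonyl carbon gives a 1.9-fold lower number from compound 1 to compound 3 (0.28 log units; within the scatter). Going by these compounds alone, this is the first step read at this position, and it shows that the two groups cannot be told apart here, although benzyloxy puts an oxygen on the carbonyl carbon and brings no fluorine. Nothing measured here gives a reason for this result. Still open, as far as these compounds go, is how a carboxylic acid, an amine or a longer chain in place of benzyloxy on this carbonyl carbon would read.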